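Chloro to trifluoromethyl on two benzimidazole-type cores

The source may report more compounds than this note shows. Statements on the series, on what has been measured and on what is new or still open speak of the compounds shown alone.

Values in an ADME assay on BHK-21 cells (Mesocricetus auratus) for cytotoxicity, read by MTT assay (on this read-out higher numbers stand for lower toxicity in this test and lower numbers for higher toxicity in this test), so far:
compound 1 `C/C(=N\NC(N)=S)c1ccc2[nH]c(-c3ccc(Cl)cc3)nc2c1` — > 100000 nM, a limit of the assay
compound 2 `C/C(=N\NC(N)=S)c1ccc2[nH]c(-c3ccc(C(F)(F)F)cc3)nc2c1` — 5000 nM
compound 3 `CC(=O)c1ccc2c(c1)nc(-c1ccc(Cl)cc1)n2C1CCCCC1` — > 100000 nM, a limit of the assay

Compound 1 and compound 2 differ by trifluoromethyl in place of chloro on an aromatic carbon. The step is an at least 20-fold lower number from compound 1 to compound 2 (1.30 log units; beyond the scatter); its size is bounded because the limit of > 100000 nM in this assay, at which 2 of the 3 values shown sit, marks where compound 1 sits. Compound 3 carries a different core; the difference between the two cores is not broken down here. Compound 4 `CC(=O)c1ccc2c(c1)nc(-c1ccc(C(F)(F)F)cc1)n2C1CCCCC1` is not yet measured in this assay and stands to compound 3 as trifluoromethyl in place of chloro on an aromatic carbon, the same kind of change seen from compound 1 to compound 2, with the place described in the same words. For compound 4 a step like an at least 5.0-fold lower number from compound 3 to compound 4 (0.69 log units; beyond the scatter) is expected, resting on compound 1 and compound 2 with an at least 20-fold lower number from compound 1 to compound 2 (1.30 log units; beyond the scatter), though compound 3 sits at a limit so the start point is uncertain. Compound 4 is estimated at 20000 nM, between 4000 nM and 100000 nM.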

Compound 4, half-maximal cytotoxic concentration: 33000 nM
For compound 4 the middle estimate is 1.7-fold (0.22 log units) below the measured one; measured number inside the range.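

In this assay the change from chloro to trifluoromethyl gives an at least 3.0-fold lower number from compound 3 to compound 4 (0.48 log units; beyond the scatter), the same direction as on the core of compound 1. Two cores show that the direction carried over in this pair of cases, and they support no rule for the whole series. Compound 1 and compound 3 each start at a limit of the assay, so the true size of neither step is known and equal size on the two cores is not shown: the same change on two cores in this assay, an at least 20-fold lower number (1.30 log units; beyond the scatter) from compound 1 to compound 2 and an at least 3.0-fold lower number (0.48 log units; beyond the scatter) from compound 3 to compound 4; the limit leaves it open whether they differ

Open, going by these compounds, is whether another group in the same place, such as a nitrile or an amine, would move the number in the same direction. Also open, on these data alone, is whether the step from chloro to trifluoromethyl would appear on a third core.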